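Swapping the aryl group on the oxadiazole core

The source may hold more compounds than are shown below. What is called first, only, known or untested is meant among the compounds shown, and "the series" means these compounds.

Measured so far in an assay on T-REx-293 cells for inhibition of potassium channel subfamily T member 1 (Homo sapiens), read by patch clamp; a lower number here means a stronger inhibitor, a higher number a weaker inhibitor:
compound 1 `CCc1cc(C(=O)N[C@@H](C)c2nc(-c3cccc(C)c3)no2)n(C)n1` — 335 nM
compound 2 `Cc1cccc(-c2nnc([C@H](C)NC(=O)c3cc(C4CC4)nn3C)o2)c1` — > 30000 nM
compound 3 `Cc1cncc(-c2noc([C@H](C)NC(=O)c3cc(C(F)(F)F)nn3C)n2)c1` — 1370 nM

Compound 3 stands at the higher of the two numbers that this assay has returned: compound 1 gives a lower number, and the gap between the two lies beyond the usual scatter of the assay. For compound 2 this assay reports only a limit, (the limit of > 30000 nM in this assay, at which 1 of the 3 values shown sits), and no number.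

The next step starts from compound 3 and leads to compound 4 `C[C@H](NC(=O)c1cc(C(F)(F)F)nn1C)c1nc(-c2ccnc(C3CC3)c2)no1`, which has not yet been measured in this assay. The structures differ in one place (2-cyclopropylpyridin-4-yl in place of 5-methylpyridin-3-yl on an aromatic carbon). The change sits on an aromatic carbon of the five-membered ring that carries the side chain, and it replaces one six-membered aromatic ring with one hetero atom by another of the same kind that also carries a three-membered non-aromatic ring of carbon only.

Going by the values given here, no measured pair shows what such a swap does here, so the expected step from compound 3 to compound 4 is set close to nothing beyond the scatter, a 1.4-fold lower number from compound 3 to compound 4 (0.14 log units; within the scatter), with wide uncertainty. Compound 4 is therefore estimated at 1000 nM, within a range from 300 nM to 4000 nM.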

Compound 4, half-maximal inhibitory concentration: 16 nM
Compound 4: middle estimate off by 63-fold (1.80 log units), on the high side; the measured number lies below the stated range.
By their numbers in this assay, from the lowest: compound 4; then compound 1; then compound 3. At a limit, above all of these: compound 2.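

In this assay, the group on the aromatic carbon between two ring nitrogen atoms proves a strong lever on the number: putting 2-cyclopropylpyridin-4-yl in place of 5-methylpyridin-3-yl gives an 86-fold lower number from compound 3 to compound 4 (1.93 log units; beyond the scatter). Going by these compounds alone, the earlier compounds offered no pair differing in one place, and this large step is the first direct reading of what this position can do, with the hydrogen-bond donor and acceptor counts and the absence of net charge the same on both sides of the swap. Nothing measured here bears on why the number falls so far.

The single step changes two things together, the methyl group giving way to cyclopropyl and the pyridin-3-yl attachment giving way to pyridin-4-yl, and the compounds shown do not separate their contributions. From the compounds shown here alone, it also remains open whether a methoxy group, an amine or an isopropyl group in the place of the cyclopropyl on the same pyridin-4-yl ring would hold the number, and whether the step carries over to cores bearing other groups on the amide side.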